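Ring-closed amine on the cinnamoyl side of the carbamate

The compounds below may be only part of what the source reports. "The series", "measured", "known", "first", "only" and "open" are said of these compounds alone.

The compounds measured so far in an assay on cells for inhibition of Amine oxidase [flavin-containing] B (Homo sapiens), read by fluorescence, with a stated time of 30 min (a lower number here means a stronger inhibitor, a higher number a weaker inhibitor), are:
compound 1 `CN(C)c1ccc(/C=C/C(=O)c2ccc(O)cc2O)cc1` with 310 nM
compound 2 `CCN(CC)C(=O)Oc1ccc(C(=O)/C=C/c2ccc(N(C)C)cc2)c(O)c1` with 3500 nM
compound 3 `CCN(CC)c1ccc(/C=C/C(=O)c2ccc(OC(=O)N3CCCC3)cc2O)cc1` with 6700 nM

Compound 3 gives the highest number of the three in this assay; its nearest neighbour is compound 2, and what the two values show lies within the usual scatter, while compound 1 stands far lower. Within the data shown here, the only single-step change measured is an 11-fold higher number from compound 1 to compound 2 (1.05 log units; beyond the scatter), which concerns the carbamate on the phenol oxygen and not the amine on the other ring. Compound 4 `O=C(/C=C/c1ccc(N2CCCCC2)cc1)c1ccc(OC(=O)N2CCCC2)cc1O` is to be measured next. It differs from compound 3 by piperidin-1-yl in place of diethylamino on an aromatic carbon. Among the measured compounds shown here, no measured pair isolates this change, so the account has nothing to rest on for its direction. The estimate for compound 4 is therefore a step of a 1.1-fold lower number from compound 3 to compound 4 (0.05 log units; within the scatter), that is, no shift beyond the scatter in this assay. Compound 4 is expected to give about 6000 nM in this assay, within a range of 2500 nM to 15000 nM.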

Compound 4, half-maximal inhibitory concentration: 780 nM
The estimate for compound 4 lay 7.7-fold (0.89 log units) above the measured number; measured number below the stated range.
By their numbers in this assay, from the lowest: compound 1; then compound 4; then compounds 2 and 3 (each within the scatter of the next).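

In this assay, replacing diethylamino with piperidin-1-yl on the aromatic carbon gives an 8.6-fold lower number from compound 3 to compound 4 (0.93 log units; beyond the scatter), with the carbamate on the other ring unchanged. Among these compounds, the only single-place step available before this one concerned the phenol oxygen, so this is the first measured sign that the amine alone can shift the number beyond the scatter. No measurement on these compounds accounts for the shift.

The compounds shown leave open whether closing the amine into a ring matters in itself or whether this one six-membered ring is special, a question that morpholin-4-yl or pyrrolidin-1-yl at the same aromatic carbon would help to settle. They also leave open whether the same amine change would give a step of similar size with a different carbamate on the phenol oxygen, such as diethylcarbamoyl.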